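A few compounds are considered here, and "the series" means these few. Any claim that something is new, unique, unknown or untested is made for them only; others in the source may bear on it.

Working notes on the series. Compound 1 `CC(=O)N1CCN(C(=O)[C@@H]2CC[C@@H](C)N2C(=O)C2=C(C(C)C)N3C(=N[C@@](C)(c4ccc(Cl)cc4)[C@H]3c3ccc(Cl)cc3)S2)CC1` gives 79 ug/mL in a physicochemical assay for solubility, read by HPLC, in phosphate buffer, at pH 6.8 (a higher number here means a more soluble compound, a lower number a less soluble compound), and holds the highest of the three numbers in hand. Compound 3 `CC[C@@H]1CC[C@@H](C(=O)N2CCN(C(C)=O)CC2)N1C(=O)C1=C(C(C)C)N2C(=N[C@@](C)(c3ccc(Cl)cc3)[C@H]2c2ccc(Cl)cc2)S1` gives 34 ug/mL; the step of a 2.3-fold lower number from compound 1 to compound 3 (0.37 log units; beyond the scatter) goes with methyl in place of hydrogen on a saturated chain carbon bound to a saturated ring carbon. Compound 2 `CC[C@@H]1CC[C@@H](C(=O)N2CCN(C)CC2)N1C(=O)C1=C(C(C)C)N2C(=N[C@@](C)(c3ccc(Cl)cc3)[C@H]2c2ccc(Cl)cc2)S1` gives 13 ug/mL; the step of a 2.6-fold higher number from compound 2 to compound 3 (0.42 log units; beyond the scatter) goes with acetyl in place of methyl on an amine nitrogen in a ring. Compound 4 `CC(C)C1=C(C(=O)N2[C@H](C)CC[C@H]2C(=O)N2CCN(C)C(C)(C)C2)SC2=N[C@@](C)(c3ccc(Cl)cc3)[C@@H](c3ccc(Cl)cc3)N21` differs from compound 1 by a group of 9 heavy atoms (7 carbon, 2 nitrogen; one six-membered non-aromatic ring with 2 hetero atoms) in place of a group of 9 heavy atoms (6 carbon, 2 nitrogen, 1 oxygen; one six-membered non-aromatic ring with 2 hetero atoms), on a carbonyl carbon. The step of a 2.6-fold higher number from compound 2 to compound 3 (0.42 log units; beyond the scatter) bears on this, and compound 4 runs that exchange the other way, so a modest fall in this assay is expected. The expected step is a 2.6-fold lower number from compound 1 to compound 4 (0.42 log units; beyond the scatter). Compound 4 is estimated at 30 ug/mL, within 12 ug/mL to 75 ug/mL.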

Compound 4, solubility: 30 ug/mL
Estimate against measurement, compound 4: no gap at the digits printed; low and high end bracket the measured number.
By their numbers in this assay, from the lowest: compound 2; then compounds 4 and 3 (each within the scatter of the next); then compound 1.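

With the acetyl group of 4-acetylpiperazin-1-yl gone from this carbonyl carbon, a 2.6-fold lower number from compound 1 to compound 4 (0.42 log units; beyond the scatter). This runs the same way as a 2.6-fold higher number from compound 2 to compound 3 (0.42 log units; beyond the scatter), so the acetyl-bearing group also gives the higher number with compound 1's methyl-substituted saturated ring, not only with the ethyl-substituted ring of compound 3. No measurement here accounts for the step.

The entering group also carries extra ring methyl groups, so the step cannot be assigned between these and the loss of acetyl. On these data alone, a plain 4-methylpiperazin-1-yl or a carboxylic acid on this carbonyl carbon remains open.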